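The source may hold more compounds than are shown below. What is called first, only, known or untested is meant among the compounds shown, and "the series" means these compounds.

Measured so far:
compound 1 `Cc1ncc([N+](=O)[O-])n1CC(=O)NS(=O)(=O)c1ccc(Cl)cc1`, 2.47 ug/mL
compound 2 `Cc1ncc([N+](=O)[O-])n1CC(=O)NS(=O)(=O)c1ccc(F)cc1`, 1.26 ug/mL
compound 3 `O=C(Cc1ccc(F)cc1)NS(=O)(=O)c1ccc(F)cc1`, 5.64 ug/mL

All three were tested in a functional assay on A549 cells (Homo sapiens) for antiproliferative activity, read by MTT assay, with a stated time of 48 h; on this read-out higher numbers stand for weaker inhibition and lower numbers for stronger inhibition. Compound 2 holds the lowest number of the three, but the distance to compound 1 is small: the step of a 2.0-fold lower number from compound 1 to compound 2 (0.29 log units; within the scatter) lies within the scatter, so nothing separates the two. Compound 3 stands further off; its value of 5.64 ug/mL sits well above that of compound 2, and this is the only gap here that exceeds the scatter.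

Compound 4 `Cc1ncc([N+](=O)[O-])n1CC(=O)NS(=O)(=O)c1ccccc1` has not yet been measured. It differs from compound 2 in one place: hydrogen in place of fluoro on an aromatic carbon. Among the compounds with values here, the only measured step touching this ring is the exchange of chloro for fluoro at the same place, from compound 1 to compound 2, which gave a 2.0-fold lower number from compound 1 to compound 2 (0.29 log units; within the scatter). Swapping one halogen for another there barely moved the number; removing the halogen altogether is a related but not identical change, and no measured pair shows it directly.

On this basis compound 4 is expected to land close to compound 2, with a step of a 1.4-fold higher number from compound 2 to compound 4 (0.15 log units; within the scatter) that stays within the scatter. The estimate for compound 4 in this assay is 1.8 ug/mL, within a range from 0.8 ug/mL to 4.5 ug/mL.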

Compound 4, half-maximal inhibitory concentration: 3.96 ug/mL
For compound 4 the middle estimate is 2.2-fold (0.34 log units) below the measured one; the range from low to high includes it.
By their numbers in this assay, from the lowest: compounds 2, 1, 4 and 3 (each within the scatter of the next, the first and the last beyond it).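

In this assay, within the data shown here, the change from 4-fluorophenyl to phenyl gives a 3.1-fold higher number from compound 2 to compound 4 (0.50 log units; beyond the scatter), the first step on this ring that lies beyond the scatter, so the fluoro group at this position is not interchangeable with a plain hydrogen. The matching exchange from chloro gives a 1.6-fold higher number from compound 1 to compound 4 (0.20 log units; within the scatter) and stays within the scatter, so compound 1 and compound 4 cannot be told apart, and neither can compound 1 and compound 2; chloro therefore sits within the scatter of both fluoro and hydrogen, and only the fluoro and hydrogen compounds are clearly separated. Nothing available explains why removing the fluoro group has this effect, and the comparison records only the size of the step.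

The compounds shown cover only hydrogen, fluoro and chloro at this one place on the ring, so it remains open whether a methoxy group, an amine or a carboxylic acid there would give a number as low as that of compound 2. From the compounds shown here alone, it also remains open whether fluoro would matter as much at another carbon of the ring, or on a core other than that of compound 2.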